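Swapping Furan-2-yl for Thiophen-2-yl on the Shared Core

This account rests on a few compounds, and the source may have more. Where it says the series, first, only, none or still open, it means among the compounds named here.

Among the measured compounds shown here, compound 2 `Nc1nc(-c2ccco2)nc2cn(-c3ccccc3O)nc12` gives 372 nM in an assay on CHO cells for displacement of a labelled ligand from adenosine receptor A1 (Homo sapiens), read by scintillation counting, with a stated time of 120 min (a lower number here means a stronger inhibitor, a higher number a weaker inhibitor), the highest of the two numbers measured so far. For the measured compounds named here, its nearest neighbour is compound 1 `Nc1nc(Cc2ccccc2)nc2cn(-c3ccccc3O)nc12`, which gives 52 nM in this assay; the only measured step, a 7.2-fold higher number from compound 1 to compound 2 (0.85 log units; beyond the scatter), exchanged benzyl for furan-2-yl on an aromatic carbon. Compound 3 `Nc1nc(-c2cccs2)nc2cn(-c3ccccc3O)nc12` differs from compound 2 by thiophen-2-yl in place of furan-2-yl on an aromatic carbon. Going by the values given here, no measured step exchanges one five-membered aromatic ring for another, so the benzyl-to-furan step shows only how far this position can shift the number at all. Furan-2-yl and thiophen-2-yl are each counted as a five-membered aromatic ring with one hetero atom, and compound 3 is therefore expected to stay near compound 2, with an expected step of a 1.5-fold lower number from compound 2 to compound 3 (0.17 log units; within the scatter). The estimate for compound 3 is 250 nM, within a range from 90 nM to 700 nM.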

Compound 3, inhibition constant: 159 nM
Compound 3: middle estimate off by 1.6-fold (0.20 log units), on the high side; the range from low to high includes it.
By their numbers in this assay, from the lowest: compound 1; then compound 3; then compound 2.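

Among the compounds shown here, the first exchange of one five-membered aromatic ring for another at this position gives a change beyond the scatter in this assay (a 2.3-fold lower number from compound 2 to compound 3 (0.37 log units; beyond the scatter)), so sulfur in place of oxygen matters here even though the counts under comparison stay the same. Thiophen-2-yl still does not reach benzyl (a 3.1-fold higher number from compound 1 to compound 3 (0.49 log units; beyond the scatter)), which places compound 3 in the middle of the three compounds and shows that this ring exchange closes only part of the gap left by the benzyl-to-furan-2-yl change. Nothing available explains why the sulfur ring gives the lower number.

From the compounds shown here alone, how an amine or a longer carbon chain would fare on this aromatic carbon remains open. Also open, going by these compounds, is whether the furan-2-yl to thiophen-2-yl step would keep its size with other groups elsewhere on the shared core.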